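Methyl for cyclopropyl on the sulfonyl of compound 3

The source may report more compounds than this note shows. Statements on the series, on what has been measured and on what is new or still open speak of the compounds shown alone.

In an ADME assay on microsomes from liver (Rattus norvegicus) for metabolic stability, with a stated time of 10 min, tested at 0.5 uM (a lower number here means that less of the compound is left, a higher number that more of the compound is left), compound 3 `Cn1cc(-c2ccc(C(F)(F)F)cc2)c2ccc(C(=O)NS(=O)(=O)C3CC3)cc21` gives 92%, the highest of the three numbers measured. Compound 2 `Cn1cc(-c2ccc(C(F)F)cc2)c2cc(F)c(C(=O)NS(=O)(=O)C3CC3)cc21` lies nearest, with 82% in this assay, a gap within the usual scatter. Compound 1 `CC(C)COc1ncc(-c2cn(C)c3cc(C(=O)NS(C)(=O)=O)ccc23)cc1Cl`, which carries a methylsulfonyl group, gives 66% in this assay, a gap to compound 3 that goes beyond the scatter, though the two compounds differ in several places.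

Compound 4 `Cn1cc(-c2ccc(C(F)(F)F)cc2)c2ccc(C(=O)NS(C)(=O)=O)cc21` is obtained from compound 3 by one change: methyl in place of cyclopropyl on a sulfonyl sulfur. Going by the values given here, no pair of measured compounds differs only in this way. Given the value of compound 1 66%, a modest fall is expected, a number 8 percentage points lower from compound 3 to compound 4 (within the scatter), most likely within the scatter. Compound 4 is therefore expected to give about 84% in this assay, between 68% and 95%.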

Compound 4, percent of the compound remaining: 74%
For compound 4 the middle estimate is 10 percentage points above the measured one; measured number inside the range.
By their numbers in this assay, from the lowest: compounds 1, 4, 2 and 3 (each within the scatter of the next, the first and the last beyond it).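

In this assay, going by these compounds alone, methyl in place of cyclopropyl on a sulfonyl sulfur gives a number 18 percentage points lower from compound 3 to compound 4 (beyond the scatter) and so provides the first reading of this change with the rest of the compound held constant. Compound 1 also carries methylsulfonyl, but it differs from the others in several places and could not isolate the change. Nothing measured here explains the step. This single pair leaves open whether the step recurs on another core. It also leaves open how an ethyl, isopropyl or dimethylamino group on the same sulfur would read.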